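This account rests on a few compounds, and the source may have more. Where it says the series, first, only, none or still open, it means among the compounds named here.

Among the measured compounds shown here, in an ADME assay (liver) for metabolic stability, with Liver microsome (Homo sapiens) as the target, read by LC-MS, using microsomes and NADPH, with a stated time of 5 min, at 37 degrees C (a higher number here means faster removal of the compound, a lower number slower removal), compound 2 `CCn1c([C@@H](C)NS(=O)(=O)c2ccccc2)nc2ccc(C(F)(F)F)cc21` gives 14 mL.min-1.g-1, the only exact number among the three compounds measured so far. Compound 1 `CCn1c([C@@H](C)NS(=O)(=O)c2ccc(Cl)cc2)nc2ccccc21` gives > 100 mL.min-1.g-1, which is a limit of the assay and not a number. Compound 3 `CCn1c([C@@H](C)NS(=O)(=O)c2ccc(NC(C)=O)c(C)c2)nc2ccc(C(F)(F)F)cc21` gives > 100 mL.min-1.g-1, which is likewise a limit. Compound 4 `CCn1c([C@@H](C)NS(=O)(=O)c2c(F)cc(F)cc2F)nc2ccc(C(F)(F)F)cc21` keeps the core of compound 2 but carries 2,4,6-trifluorophenyl in place of phenyl on a sulfonyl sulfur. For the measured compounds named here, no measured pair of compounds differs by this change, so its size can only be judged by expectation. The expected step of a 1.4-fold higher number from compound 2 to compound 4 (0.15 log units; within the scatter) is small and upward in this assay, hardly beyond the scatter. For compound 4 the estimated value is 20 mL.min-1.g-1, with an expected range of 8 mL.min-1.g-1 to 50 mL.min-1.g-1.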

Compound 4, intrinsic clearance in microsomes: 19 mL.min-1.g-1
For compound 4 the middle estimate is 1.1-fold (0.02 log units) above the measured one, and the stated range covers the measured number.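

In this assay, 2,4,6-trifluorophenyl in place of phenyl on a sulfonyl sulfur gives a 1.4-fold higher number from compound 2 to compound 4 (0.13 log units; within the scatter). Among the compounds shown here, this is the first single change that can be read at this position, and it shows that three fluorine atoms can enter there without a reading distinguishable from that of compound 2. Compound 4 also gives an exact number and not a limit of the assay: the limit of > 100 mL.min-1.g-1 in this assay, at which 2 of the 4 values shown sit.

On these data alone, whether an amine or a carboxylic acid on the phenyl ring would also give an exact number stays open. So does the effect of a single fluorine there.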